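The source may report more compounds than this note shows. Statements on the series, on what has been measured and on what is new or still open speak of the compounds shown alone.

Measured so far in a functional assay on A549 cells (Homo sapiens) for inhibition, read by MTT assay, with a stated time of 72 h; a lower number here means a stronger inhibitor, a higher number a weaker inhibitor:
- compound 1 `CNC(=O)CCCCCCCn1nc(-c2cnc3[nH]ccc3c2)c2c(N)ncnc21`: 51000 nM
- compound 2 `Nc1ncnc2c1c(-c1cnc3[nH]ccc3c1)nn2CCCCCCCCC(=O)NO`: 12300 nM
- compound 3 `Nc1nc2cc(-c3nn(CCCCCCCCCC(=O)NO)c4ncnc(N)c34)ccc2o1`: > 50000 nM (a limit)

Compound 3 has no number in this assay, only the limit > 50000 nM. It stands at the limit of > 50000 nM in this assay, at which 1 of the 3 values shown sits.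

Compound 4 `Nc1ncnc2c1c(-c1cnc3[nH]ccc3c1)nn2CCCCCCCCCC(=O)NO` is still to be measured. Its difference from compound 3 is a group of 9 heavy atoms (7 carbon, 2 nitrogen; one five-membered aromatic ring with 1 hetero atom, one six-membered aromatic ring with 1 hetero atom) in place of a group of 10 heavy atoms (7 carbon, 2 nitrogen, 1 oxygen; one five-membered aromatic ring with 2 hetero atoms, one six-membered aromatic ring of carbon only), on an aromatic carbon. The 2-amino-1,3-benzoxazol-5-yl group leaves, and the change sits on an aromatic carbon of a five-membered aromatic ring with 2 nitrogen.

Among the compounds with values here, no measured step makes this exchange, so the evidence is indirect. Within the data shown here, the only measured step, a 4.1-fold lower number from compound 1 to compound 2 (0.62 log units; beyond the scatter), is a modest one beyond the scatter, and it changes the chain end rather than this aromatic group. It does suggest that the chain end of compound 4 is the more favourable of the two seen with the entering group. Compound 2 carries the entering group and gives 12300 nM, so a value near that of compound 2 is the working expectation. A lower number than the limit of compound 3 is therefore expected, though a second limit cannot be excluded.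

The expected step is an at least 3.5-fold lower number from compound 3 to compound 4 (0.55 log units; beyond the scatter). For compound 4 the estimate is 14000 nM, with an expected range of 4500 nM to 45000 nM.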

Compound 4, half-maximal inhibitory concentration: 6550 nM
The estimate for compound 4 lay 2.1-fold (0.33 log units) above the measured number, within the range that was stated.
By their numbers in this assay, from the lowest: compounds 4 and 2 (each within the scatter of the next); then compound 1.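

this assay gives an at least 7.6-fold lower number from compound 3 to compound 4 (0.88 log units; beyond the scatter), the first measured exchange at this aromatic carbon of the five-membered aromatic ring with 2 nitrogen, made with the chain and its hydroxycarbamoyl end held fixed. The size of that step is bounded on one side only, as compound 3 gives a limit and not a number: the limit of > 50000 nM in this assay, at which 1 of the 4 values shown sits. With the entering group kept, (hydroxycarbamoyl)methyl in place of hydroxycarbamoyl gives a 1.9-fold lower number from compound 2 to compound 4 (0.27 log units; within the scatter), so this chain change is not resolved, while 2-(hydroxycarbamoyl)ethyl in place of methylcarbamoyl gives a 7.8-fold lower number from compound 1 to compound 4 (0.89 log units; beyond the scatter).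

Still open, from the compounds shown here alone, is how a plain phenyl group at this aromatic carbon would compare with the two groups seen, which would help show whether the 2-amino-1,3-benzoxazol-5-yl result follows its amine or its ring system. Also open, going by these compounds, is how a carboxylic acid in place of the hydroxycarbamoyl end, or a longer chain, would read with the entering group in place.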